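This account rests on a few compounds, and the source may have more. Where it says the series, first, only, none or still open, it means among the compounds named here.

In a functional assay on K562 cells (Homo sapiens) for antiproliferative activity, read by MTT assay, with a stated time of 72 h (on this read-out higher numbers stand for weaker inhibition and lower numbers for stronger inhibition), compound 1 `COc1cccc(-c2ncnn2-c2cc(OC)c(OC)c(OC)c2)c1` gives > 10000 nM, which is a limit of the assay and not a number. Compound 2 `CCOc1cccc(-c2ncnn2-c2cc(OC)c(OC)c(OC)c2)c1` gives > 10000 nM, which is also a limit. Compound 3 `COc1cc(-n2ncnc2-c2ccccc2)cc(OC)c1OC` gives > 10000 nM, again a limit and not a number. Compound 3 therefore has no exact position on the scale, and the record so far is the limit of > 10000 nM in this assay, at which 3 of the 3 values shown sit.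

The next compound is compound 4 `COc1cc(-n2ncnc2-c2cccc([N+](=O)[O-])c2)cc(OC)c1OC`. It differs from compound 3 by a single change, nitro in place of hydrogen on an aromatic carbon.

Two measured steps also concern a group on an aromatic carbon, namely a step that the two limits leave unreadable from compound 1 to compound 3 and a step that the two limits leave unreadable from compound 2 to compound 3. Neither has a size that can be read. The remaining measured step, a step that the two limits leave unreadable from compound 1 to compound 2, is just as uninformative. These steps therefore give no measured size or direction to carry over to the new change. No step beyond the usual scatter is expected in this assay, and another limit is the most likely report. The expected change is a number no higher from compound 3 to compound 4 (the limit leaves the size open), an estimate resting on limits alone. For compound 4 the estimated value is 10000 nM, with an expected range from 3000 nM to 30000 nM.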

Compound 4, half-maximal inhibitory concentration: > 10000 nM
Compound 4: no number, only a limit (the forecaster's own chance of this, stated with the estimate: 70%); the middle value sits exactly at the limit.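

In this assay compound 4 gives > 10000 nM, which is a limit and not a number. The steps linking compound 4 to compound 1, compound 2 and compound 3 therefore cannot be read. The compounds shown leave open how strongly any of them inhibits, and whether any change in one place would give a measurable number, since all share one result: the limit of > 10000 nM in this assay, at which 4 of the 4 values shown sit.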